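Methyl on a Ring Amide Nitrogen: Expecting Compound 4

A few compounds are considered here, and "the series" means these few. Any claim that something is new, unique, unknown or untested is made for them only; others in the source may bear on it.

Four related compounds are examined in a functional assay on the whole organism (strain Wister albino) for inhibition, with Rattus norvegicus as the target, read by paw edema, with stated times of 1 h and 4 h, at a dose of 50 mg/kg by the intraperitoneal route; on this read-out higher numbers stand for more inhibition at the one dose given (going by the name of the read-out) and lower numbers for less inhibition. Compound 1 `CN1C/C(=C\c2ccccc2)C(=O)[C@]2(C1)[C@@H](c1ccccc1)CN(C)[C@@]21C(=O)Nc2ccccc21` gives 70.9%, and its close relative compound 2 `CN1C/C(=C\c2ccccc2)C(=O)[C@]2(C1)[C@@H](c1ccccc1)CN(C)[C@@]21C(=O)N(C)c2ccccc21` gives 68.8%. Compound 3 `CN1C/C(=C\c2ccc(Br)cc2)C(=O)[C@]2(C1)[C@@H](c1ccc(Br)cc1)CN(C)[C@@]21C(=O)Nc2ccccc21`, which carries a bromine on each of its two outer benzene rings, gives 66.8%. On the numbers shown, compound 3 has the lowest value of the three, yet its gap to compound 2 and its gap to compound 1 both lie within the usual scatter, so the three measured compounds cannot be told apart with any confidence.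

The unmeasured compound 4 `CN1C/C(=C\c2ccc(Br)cc2)C(=O)[C@]2(C1)[C@@H](c1ccc(Br)cc1)CN(C)[C@@]21C(=O)N(C)c2ccccc21` differs from compound 3 in one place: methyl in place of hydrogen on an amide-type nitrogen in a ring. The same change has already been made once, between compound 1 and compound 2, where it produced a number 2.1 percentage points lower from compound 1 to compound 2 (within the scatter). That single precedent suggests the change makes no difference that rises above the scatter of this assay. Among the compounds with values here, no other measured pair bears on it.

Compound 4 is therefore expected to land close to compound 3, with a step of a number 1.8 percentage points lower from compound 3 to compound 4 (within the scatter) that stays within the scatter. The estimated value for compound 4 is 65%, with a likely range from 55% to 75%.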

Compound 4, a percentage reported as inhibition, in the whole organism at one dose (the size of the read-out at that dose, not a potency): 46.8%
For compound 4 the middle estimate is 18.2 percentage points above the measured one, outside the stated range (below it).
By their numbers in this assay, from the lowest: compound 4; then compounds 3, 2 and 1 (each within the scatter of the next).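

In this assay, the methyl in place of the amide hydrogen on this ring nitrogen is not always a harmless swap, since the result here is a number 20 percentage points lower from compound 3 to compound 4 (beyond the scatter). Compound 1 and compound 2 alone gave no sign of this, and the new pair shows that the same small change at the same place can have a very different outcome depending on the rest of the molecule: the same change on two cores in this assay, a number 2.1 percentage points lower (within the scatter) from compound 1 to compound 2 and a number 20 percentage points lower (beyond the scatter) from compound 3 to compound 4, 17.9 percentage points apart, beyond the scatter of two such steps The core of compound 3 differs from the core of compound 1 by a bromine on each of the two outer benzene rings, so in these two pairs the clear drop appears only where those bromines are present, though two pairs are too few to make this a general rule.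

Which of the two bromines matters remains open, as does whether chlorine or a methoxy group in their place would go with the same drop. As far as these compounds go, it is also open how an ethyl group or a longer chain on this nitrogen would behave on either core.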